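Regioisomeric bromo-benzoic acids on a shared core

This account rests on a few compounds, and the source may have more. Where it says the series, first, only, none or still open, it means among the compounds named here.

Measured compounds:
- compound 1, `CC#CCn1c(N2CCC[C@@H](N)C2)cc(=O)n(Cc2cccc(C(=O)O)c2Br)c1=O`: in an assay on isolated protein for inhibition of Dipeptidyl peptidase 9 (Homo sapiens), read by fluorescence, with stated times of 15 min and 20 min (a lower number here means a stronger inhibitor, a higher number a weaker inhibitor), compound 1 gives "not determined" (no result reported).
- compound 2, `CC#CCn1c(N2CCC[C@@H](N)C2)cc(=O)n(Cc2ccc(Br)c(C(=O)OC)c2)c1=O`: in this assay compound 2 gives > 100 nM, which is a limit of the assay and not a number.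
- compound 3, `CC#CCn1c(N2CCC[C@@H](N)C2)cc(=O)n(Cc2ccc(Cl)c(C(=O)OC)c2)c1=O`: in this assay compound 3 gives > 100 nM, again a limit of the assay.

Compound 1 therefore has no number of its own in this assay, and the two further values shown are both limits, as noted in the limit of > 100 nM in this assay, at which 2 of the 3 values shown sit. Among the compounds with values here, the only step between measured compounds, a step that the two limits leave unreadable from compound 2 to compound 3, is left unreadable by those two limits, so it gives no measure of how large any change on this part of the molecule is.

Compound 4, `CC#CCn1c(N2CCC[C@@H](N)C2)cc(=O)n(Cc2cc(Br)cc(C(=O)O)c2)c1=O`, differs from compound 1 by 3-bromo-5-carboxyphenyl in place of 2-bromo-3-carboxyphenyl on a saturated chain carbon bound to an aromatic nitrogen. Within the data shown here, no measured step bears directly on this change, and the two measured values of the ester analogues are both limits; the expected size of the step in this assay therefore cannot be read, in either direction. Given that both measured esters sit at the limit, compound 4 is estimated at 300 nM, with an expected range from 50 nM to 3000 nM, and a considerable chance that only a limit is reported.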

Compound 4, half-maximal inhibitory concentration: > 100 nM
Compound 4: no number, only a limit (the forecaster's own chance of this, stated with the estimate: 55%); the middle value lies beyond the limit too.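

In this assay compound 4 gives > 100 nM which is a limit of the assay and not a number. Compound 1 gives "not determined" (no result reported) and so no new step can be read between compound 1 and compound 4. The compounds shown leave open how strongly each inhibits and whether 2-bromo-3-carboxyphenyl and 3-bromo-5-carboxyphenyl differ at all: the limit of > 100 nM in this assay, at which 3 of the 4 values shown sit.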